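The source may hold more compounds than are shown below. What is called first, only, known or untested is meant among the compounds shown, and "the series" means these compounds.

- compound 1 `CC(=O)SCCC(CCCCC(=O)O)SC(C)=O`: 6.04%
- compound 2 `O=C(CCCCC1CCSS1)Nc1ccc(Cl)cn1`: 33.7%
- compound 3 `CC(=O)SCCC(CCCCC(=O)Nc1ccccc1Cl)SC(C)=O`: 11.4%

In a functional assay on NCI-H460 cells (Homo sapiens) for inhibition, read by MTT assay, with a stated time of 24 h, tested at 10 ug/mL (a higher number here means more inhibition of growth at the concentration tested, a lower number less inhibition of growth), compound 3 gives 11.4% and sits within the scatter of compound 1, while compound 2 stands clearly higher. Compound 4 `CC(=O)SCCC(CCCCC(=O)Nc1ccc(Cl)cc1)SC(C)=O` carries 4-chlorophenyl in place of 2-chlorophenyl on an amide-type nitrogen. The nearest measured step is a number 5.4 percentage points higher from compound 1 to compound 3 (within the scatter) and it concerns (2-chlorophenyl)amino in place of hydroxy on a carbonyl carbon. Going by the values given here, no measured pair compares 2-chlorophenyl with 4-chlorophenyl, so this step offers only a rough guide to size. The expected result is a number 1.6 percentage points higher from compound 3 to compound 4 (within the scatter) and no step beyond the scatter is expected. Compound 4 is estimated at 13% (expected range 3% to 28%).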

Compound 4, percent growth inhibition at one concentration: 14.9%
The estimate for compound 4 lay 1.9 percentage points below the measured number; low and high end bracket the measured number.
By their numbers in this assay, from the lowest: compounds 1, 3 and 4 (each within the scatter of the next); then compound 2.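

In this assay the swap of 2-chlorophenyl for 4-chlorophenyl on the amide-type nitrogen gives a number 3.5 percentage points higher from compound 3 to compound 4 (within the scatter), so this change has no readable effect at this position. Even the full replacement of hydroxy on the carbonyl carbon by (4-chlorophenyl)amino gives only a number 8.9 percentage points higher from compound 1 to compound 4 (within the scatter), which means neither chlorophenyl amide stands apart from the parent acid. Nothing available here offers an explanation for these results. Still open, going by these compounds, is whether 3-chlorophenyl, 4-methoxyphenyl or 4-aminophenyl on this nitrogen would move growth inhibition beyond the scatter.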